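The source may hold more compounds than are shown below. What is called first, only, known or untested is meant among the compounds shown, and "the series" means these compounds.

Measured so far:
Compound 1 `Cc1ccc2c(NCc3ccc(NC(=O)C4CCN(Cc5ccccc5)CC4)cc3)nc(N3CCN[C@@H](C)C3)nc2c1`: in a functional assay on SV5A8 cells (Homo sapiens) for cytotoxicity (on this read-out higher numbers stand for weaker inhibition and lower numbers for stronger inhibition), compound 1 gives > 8860 nM, which is a limit of the assay.
Compound 2 `Cc1ccc2c(NCc3ccc(NC(=O)C4CCN(Cc5ccccc5)CC4)cc3)nc(N3CCNC(CCO)C3)nc2c1`: in this assay compound 2 gives > 8420 nM, again a limit.
Compound 3 `Cc1ccc2c(NCc3ccc(NC(=O)C4CCN(Cc5ccccc5)CC4)cc3)nc(N(C)CCN(C)C)nc2c1`: in this assay compound 3 gives > 8830 nM, also a limit.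

Compound 3 therefore stands at a limit, as do both other values shown (the limit of > 8420 nM in this assay, at which 1 of the 3 values shown sits, (the limit of > 8830 nM in this assay, at which 1 of the 3 values shown sits), (the limit of > 8860 nM in this assay, at which 1 of the 3 values shown sits)). The steps from compound 1 to compound 2 a step that the two limits leave unreadable from compound 1 to compound 2, from compound 1 to compound 3 a step that the two limits leave unreadable from compound 1 to compound 3 and from compound 2 to compound 3 a step that the two limits leave unreadable from compound 2 to compound 3 are unreadable, since both ends sit at limits.

Compound 4 `Cc1ccc2c(NCc3ccc(NC(=O)C4CCN(Cc5ccccc5)CC4)cc3)nc(N3CCCCCC3)nc2c1` differs from compound 3 by azepan-1-yl in place of (2-(dimethylamino)ethyl)(methyl)amino on an aromatic carbon. No readable measured step bears on this change, and all three values are limits, so no step beyond the scatter is expected. The step from compound 3 to compound 4 is estimated at a step that the limit leaves unreadable from compound 3 to compound 4. Compound 4 is estimated at 9000 nM, between 3000 nM and 30000 nM, most likely again reported only as a limit.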

Compound 4, half-maximal inhibitory concentration: > 6880 nM
Compound 4 gave a limit, no number; the forecaster's own chance of this, stated with the estimate: 85%; the middle value does not contradict the limit.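

Compound 4 gives > 6880 nM, again a limit, so its steps from compound 1, compound 2 and compound 3 cannot be read. The compounds shown leave open whether exchanging these groups changes the result in this assay at all.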